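Rat half-life: 2-hydroxyethoxy in place of (pyrrolidin-1-yl)carbonyl

The source may report more compounds than this note shows. Statements on the series, on what has been measured and on what is new or still open speak of the compounds shown alone.

Two members of the series carry numbers in an in vivo ADME assay on the whole organism (strain Sprague-Dawley) for metabolic stability, with Rattus norvegicus as the target; on this read-out lower numbers stand for a shorter-lived compound and higher numbers for a longer-lived compound. Compound 1 `CCCCCOC(=O)N1CCN(C(=O)[C@H](CCC(=O)O)NC(=O)c2nc(-c3ccccc3)cc(N3CCC(COC)CC3)n2)CC1` gives 0.005 h in this assay. Compound 2 `CCCCCOC(=O)N1CCN(C(=O)[C@H](CCC(=O)O)NC(=O)c2cc(N3CCC(C(=O)N4CCCC4)CC3)nc(-c3ccccc3)n2)CC1` gives 0.0133 h in this assay, the higher of the two numbers; the nearest, and only, neighbour is compound 1, and the gap between them is beyond the scatter. Going by the values given here, no pair of measured compounds differs in a single place, so no measured single step can be drawn from this assay.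

Compound 3 `CCCCCOC(=O)N1CCN(C(=O)[C@H](CCC(=O)O)NC(=O)c2cc(N3CCC(OCCO)CC3)nc(-c3ccccc3)n2)CC1` is the next compound to go into this assay. It differs from compound 2 as follows: 2-hydroxyethoxy in place of (pyrrolidin-1-yl)carbonyl on a saturated ring carbon. Both measured compounds sit at very short half-lives, and nothing measured here shows how an exchange on the saturated ring carbon moves this assay. The step from compound 2 to compound 3 is therefore expected to be small, a 1.3-fold lower number from compound 2 to compound 3 (0.12 log units; within the scatter), in either direction within the scatter. For compound 3 the half-life in this assay is estimated at 0.01 h, with a range from 0.003 h to 0.03 h.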

Compound 3, half-life: 0.00833 h
Compound 3: the middle estimate sits 1.2-fold (0.08 log units) above what was measured; low and high end bracket the measured number.
By their numbers in this assay, from the lowest: compounds 1, 3 and 2 (each within the scatter of the next, the first and the last beyond it).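

In this assay, going by these compounds alone, the first single step at this position, a 1.6-fold lower number from compound 2 to compound 3 (0.20 log units; within the scatter), lies within the scatter, so compound 2 and compound 3 cannot be told apart on this read-out. The exchange on this saturated ring carbon, three ring bonds from the ring nitrogen, replaces 7 heavy atoms and a five-membered non-aromatic ring with 4 heavy atoms, no ring and 1 hydrogen-bond donor, yet it produces no separable difference in half-life between these two compounds. Nothing measured on these compounds speaks to what sets the half-life at this position.

Going by these compounds, whether a primary amine, a carboxylic acid or a longer 2-hydroxyalkoxy chain on the same ring carbon would give a step beyond the scatter remains open. Compound 1 differs from compound 2 and from compound 3 in more than one place, so steps from it cannot be read, and one exchange at this position cannot show whether the short half-lives of compound 2 and compound 3 depend on this ring carbon at all.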